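From Methoxy to Hydroxy: Expecting Only a Modest Shift

The compounds below may be only part of what the source reports. "The series", "measured", "known", "first", "only" and "open" are said of these compounds alone.

Of the compounds shown here, two have been measured in an assay on HEK293 cells for displacement of a labelled ligand from Neuronal acetylcholine receptor; alpha4/beta2 (Homo sapiens); a higher number here means a weaker inhibitor, a lower number a stronger inhibitor. Compound 1 `COc1cncc(N2CCCNCC2)c1` gives 1.91 nM, and compound 2 `C=COc1cc(N2CCCNCCC2)cnc1Br` gives 0.38 nM. Compound 1 thus has the higher of the two numbers, and its gap to compound 2 lies beyond the usual scatter, so compound 2 is the stronger binder of the pair. Compound 2 differs from compound 1 in several places at once, so this pair says nothing about any single change.

Compound 3 `Oc1cncc(N2CCCNCC2)c1` has not yet been measured. It differs from compound 1 in one place: hydrogen in place of methyl on an oxygen on an aromatic ring. Among the compounds with values here, no measured pair shows what this change does here, so the expectation rests on compound 1 alone. The step from compound 1 to compound 3 is estimated as a 1.6-fold higher number from compound 1 to compound 3 (0.20 log units; within the scatter), a small weakening that may not exceed the scatter. Compound 3 is expected to give about 3 nM in this assay, with a range from 0.8 nM to 12 nM.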

Compound 3, half-maximal inhibitory concentration: 2.4 nM
Compound 3: the middle estimate sits 1.3-fold (0.10 log units) above what was measured; the range from low to high includes it.
By their numbers in this assay, from the lowest: compound 2; then compounds 1 and 3 (each within the scatter of the next).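

In this assay, within the data shown here, this pair gives the first comparison that isolates a single change: going from methoxy to hydroxy is a 1.3-fold higher number from compound 1 to compound 3 (0.10 log units; within the scatter). At this oxygen on an aromatic ring, then, replacing methyl with hydrogen produces no difference that can be separated from the ordinary spread of repeated measurements. Nothing available here explains this result.

The compounds shown leave open what would happen with an ethyl or benzyl group on this oxygen, or with an amine in place of the oxygen. They also leave open whether the methoxy-to-hydroxy change would behave in the same way on the core of compound 2, which differs from compound 1 in several places.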